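Removing the Methyl on an Aromatic Nitrogen: Two Pairs

This account rests on a few compounds, and the source may have more. Where it says the series, first, only, none or still open, it means among the compounds named here.

Compound 1 `Cn1c(/C=C/C(=O)c2ccccc2O)cc(Br)c1Br`: 2510 nM
Compound 2 `COc1ccc(C(=O)/C=C/c2cc(Br)c(Br)n2C)c(OC)c1`: 80 nM
Compound 3 `O=C(/C=C/c1cc(Br)c(Br)[nH]1)c1ccccc1O`: 1490 nM

In a functional assay on MCF7 cells (Homo sapiens) for cytotoxicity, read by MTT assay, with stated times of 6 h and 48 h (a higher number here means a weaker inhibitor, a lower number a stronger inhibitor), compound 1 gives 2510 nM, and compound 3 gives 1490 nM. The change between them, (hydrogen in place of methyl on an aromatic nitrogen), made a step of a 1.7-fold lower number from compound 1 to compound 3 (0.23 log units; within the scatter). Compound 2 gives 80 nM and is the strongest of the three, its gap to each of the others lying beyond the scatter. How the core of compound 2 differs from that of compound 1 is not broken down here.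

Compound 4 `COc1ccc(C(=O)/C=C/c2cc(Br)c(Br)[nH]2)c(OC)c1` is not yet measured. It differs from compound 2 by hydrogen in place of methyl on an aromatic nitrogen, the same change as that from compound 1 to compound 3. Because that earlier step was a 1.7-fold lower number from compound 1 to compound 3 (0.23 log units; within the scatter), the expected step from compound 2 to compound 4 is similarly small, a 1.3-fold lower number from compound 2 to compound 4 (0.12 log units; within the scatter). For compound 4 the estimate in this assay is 60 nM, expected between 20 nM and 200 nM.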

Compound 4, half-maximal inhibitory concentration: 30 nM
Compound 4: middle estimate off by 2.0-fold (0.30 log units), on the high side; low and high end bracket the measured number.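

Carried onto the second core, hydrogen in place of methyl on an aromatic nitrogen gave a 2.7-fold lower number from compound 2 to compound 4 (0.43 log units; beyond the scatter) in this assay. Set beside the earlier step, this one cannot be told apart from it in size: the same change on two cores in this assay, a 1.7-fold lower number (0.23 log units; within the scatter) from compound 1 to compound 3 and a 2.7-fold lower number (0.43 log units; beyond the scatter) from compound 2 to compound 4, 1.6-fold (0.20 log units) apart, within the scatter of two such steps. The change thus carried across these two cores with no difference beyond the scatter, but two pairs in one assay do not show that it would do so on any other core, and they do not explain the step.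

The compounds shown leave open how an ethyl group or a longer chain on that nitrogen would compare with methyl and hydrogen. On these data alone, it also remains open whether the step would hold on a core bearing an amine or a carboxylic acid.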